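A few compounds are considered here, and "the series" means these few. Any claim that something is new, unique, unknown or untested is made for them only; others in the source may bear on it.

In a functional assay on HL-60 cells (Homo sapiens) for cytotoxicity, read by MTT assay, with a stated time of 48 h (a higher number here means a weaker inhibitor, a lower number a stronger inhibitor), compound 1 (`COc1ccc(-c2c[nH]c(=O)n2-c2cc(OC)c(OC)c(OC)c2)cc1`) gives 19800 nM and compound 2 (`COc1ccc(-c2c[nH]c(=O)n2-c2cc(OC)c(OC)c(OC)c2)cc1[N+](=O)[O-]`) gives 14300 nM. Compound 3 (`COc1cc(-n2c(-c3ccc([N+](=O)[O-])cc3)cn(C(C)=O)c2=O)cc(OC)c1OC`) gives 7200 nM, a value beyond the scatter from that of compound 1 but within it from that of compound 2. In compound 4 (`COc1ccc(-c2cn(C(C)=O)c(=O)n2-c2cc(OC)c(OC)c(OC)c2)cc1N`), 3-amino-4-methoxyphenyl takes the place of 4-nitrophenyl on an aromatic carbon: 3-amino-4-methoxyphenyl in place of 4-nitrophenyl on an aromatic carbon. Within the data shown here, only one measured step involves a nitro group, a 1.4-fold lower number from compound 1 to compound 2 (0.14 log units; within the scatter), and it stays within the scatter. Among the measured compounds shown here, no measured step covers an amino group. The expected change is therefore none beyond the scatter, an estimated 1.4-fold lower number from compound 3 to compound 4 (0.16 log units; within the scatter). The estimate for compound 4 is 5000 nM, with an expected range from 600 nM to 15000 nM.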

Compound 4, half-maximal inhibitory concentration: 400 nM
Beside the measured number, compound 4's estimate is 13-fold (1.10 log units) above it; the whole stated range lies above it.
By their numbers in this assay, from the lowest: compound 4; then compounds 3, 2 and 1 (each within the scatter of the next, the first and the last beyond it).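

Exchanging 4-nitrophenyl for 3-amino-4-methoxyphenyl on this aromatic carbon gives an 18-fold lower number from compound 3 to compound 4 (1.26 log units; beyond the scatter) and is a large step. Among these compounds, the only earlier step on this aromatic ring, a 1.4-fold lower number from compound 1 to compound 2 (0.14 log units; within the scatter) (within the scatter), gave no sign that the number could shift so far through a change at this position. No available evidence accounts for the size of this step.

The step changes both ring substituents at once, so the contributions of the amino and methoxy groups remain unseparated. From the compounds shown here alone, how a hydroxyl or an acetamide in place of the amino group would read also remains open.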